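The compounds below may be only part of what the source reports. "The series", "measured", "known", "first", "only" and "open" are said of these compounds alone.

Compound 2 `CS(=O)(=O)c1cnc(C(=O)CCc2ccc(-c3ccccc3)cc2)o1` is one of three compounds examined in an assay for inhibition of Fatty-acid amide hydrolase 1 (Rattus norvegicus); a lower number here means a stronger inhibitor, a higher number a weaker inhibitor. In this assay compound 2 gives 1.2 nM, the lowest of the three numbers. Compound 3 `COC(=O)c1cnc(C(=O)CCc2ccc(Oc3ccccc3)cc2)o1` gives 1.7 nM in this assay, a value that sits within the usual scatter of that of compound 2, so the two cannot be told apart. Compound 1 `NC(=O)c1cccc(-c2cnc(C(O)CCc3ccc(-c4ccccc4)cc3)o2)n1` gives 20000 nM in this assay, far beyond the scatter from compound 2.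

The step from compound 2 leads to compound 4 `COC(=O)c1cccc(-c2cnc(C(=O)CCc3ccc(-c4ccccc4)cc3)o2)n1`, which has not yet been measured in this assay. The change is 6-(methoxycarbonyl)pyridin-2-yl in place of methylsulfonyl on an aromatic carbon. Within the data shown here, no measured pair shows this exact change, so its size is not known from these data. Because compound 2 already stands at 1.2 nM, the expectation is that compound 4 stays close to it, with a step of a 1.2-fold lower number from compound 2 to compound 4 (0.08 log units; within the scatter) that is expected to be small, in either direction, and not clearly beyond the scatter. Compound 4 is therefore estimated at 1 nM, within a range from 0.3 nM to 4 nM.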

Compound 4, inhibition constant: 1.2 nM
For compound 4 the middle estimate is 1.2-fold (0.08 log units) below the measured one; the range from low to high includes it.
By their numbers in this assay, from the lowest: compounds 2, 4 and 3 (each within the scatter of the next); then compound 1.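

In this assay, placing 6-(methoxycarbonyl)pyridin-2-yl instead of methylsulfonyl on the aromatic carbon next to the ring oxygen gives no change at the digits printed from compound 2 to compound 4 (within the scatter). Among these compounds, this is the first pair here that differs in only one place, and it shows that this position can carry a group of 10 heavy atoms with a six-membered aromatic ring as well as one of 4 heavy atoms with no ring, without a readable difference in this read-out. Nothing at hand explains why these two different groups give the same result.

Going by these compounds, whether a carboxylic acid or an amine in place of the methoxycarbonyl, or a bare pyridin-2-yl, would hold this level remains open. Also open, on these data alone, is whether a longer chain at this position would do the same.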